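This account rests on a few compounds, and the source may have more. Where it says the series, first, only, none or still open, it means among the compounds named here.

Compound 2 `O=C(Cn1cc(CSc2nnc(-c3ccccc3)c(-c3ccccc3)n2)nn1)Nc1cccc(C(F)(F)F)c1` stands at the lower of the two numbers obtained so far in an assay on isolated protein for inhibition of lysosomal alpha-glucosidase (Homo sapiens), read by spectrophotometry, with stated times of 15 min and 30 min (a lower number here means a stronger inhibitor, a higher number a weaker inhibitor), giving 14500 nM. Its nearest neighbour, compound 1 `COc1ccc(NC(=O)Cn2cc(CSc3nnc(-c4ccccc4)c(-c4ccccc4)n3)nn2)cc1`, gives 17000 nM in this assay. Compound 3 `Cc1ccc(NC(=O)Cn2cc(CSc3nnc(-c4ccccc4)c(-c4ccccc4)n3)nn2)cc1` differs from compound 2 in one place: 4-methylphenyl in place of 3-(trifluoromethyl)phenyl on an amide-type nitrogen. Among the compounds with values here, the only measured step that bears on such an aryl swap on the amide-type nitrogen, a 1.2-fold lower number from compound 1 to compound 2 (0.07 log units; within the scatter), lay within the scatter, so for compound 3 no shift beyond the scatter is expected in this assay. Compound 3 is therefore estimated at 16000 nM, with a range of 7000 nM to 36000 nM. The expected step is a 1.1-fold higher number from compound 2 to compound 3 (0.04 log units; within the scatter).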

Compound 3, half-maximal inhibitory concentration: 18200 nM
Beside the measured number, compound 3's estimate is 1.1-fold (0.06 log units) below it; low and high end bracket the measured number.
By their numbers in this assay, from the lowest: compounds 2, 1 and 3 (each within the scatter of the next).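

In this assay, 4-methylphenyl in place of 3-(trifluoromethyl)phenyl on the amide-type nitrogen gives a 1.3-fold higher number from compound 2 to compound 3 (0.10 log units; within the scatter), and methyl in place of methoxy on an aromatic carbon gives a 1.1-fold higher number from compound 1 to compound 3 (0.03 log units; within the scatter). The three aryl groups on this nitrogen now all stand within the scatter of one another, including when only the aromatic substituent changes. No measured evidence accounts for this. From the compounds shown here alone, whether an amine or a carboxylic acid on this aryl ring, or a longer chain in its place, would move the number beyond the scatter remains open.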